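The source may hold more compounds than are shown below. What is called first, only, known or untested is meant among the compounds shown, and "the series" means these compounds.

Measured so far:
- Compound 1, `Cc1cc(C)c(CN2CCc3c(Cl)cc([C@@H](CO)[C@@H]4CCOC4)c(Cl)c3C2=O)c(=O)[nH]1`: 25.3 uL/min
- Compound 2, `Cc1cc(C)c(CN2CCc3c(Cl)cc([C@@H](CO)[C@H]4CCCO4)c(Cl)c3C2=O)c(=O)[nH]1`: 43 uL/min
- Compound 3, `COC(c1cc(Cl)c2c(c1Cl)C(=O)N(Cc1c(C)cc(C)[nH]c1=O)CC2)C1CCOC1`: 136 uL/min; 93.3 uL/min; 128 uL/min; 108 uL/min (4 entries)

The numbers come from an ADME assay on microsomes from liver (Homo sapiens) for metabolic stability, read by LC-MS, using NADPH, with stated times of 10 min and 45 min, tested at 1 uM; a higher number here means faster removal of the compound, a lower number slower removal. Compound 2 gives 43 uL/min, the highest of the two single numbers, while its nearest neighbour compound 1 gives 25.3 uL/min; the step of a 1.7-fold higher number from compound 1 to compound 2 (0.23 log units; within the scatter) lies within the usual scatter, so the two cannot be told apart. Compound 3 has several entries rather than one number, and their spread the several entries of compound 3 in this assay, 136 uL/min; 93.3 uL/min; 128 uL/min; 108 uL/min (4 entries) shows how much repeat measurements of the same compound can wander.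

The next compound, compound 4, is `Cc1cc(C)c(CN2CCc3c(Cl)cc([C@H](CO)[C@H]4CCOC4)c(Cl)c3C2=O)c(=O)[nH]1`. It is built from the same atoms as compound 2, joined differently: a group of 8 heavy atoms (6 carbon, 2 oxygen; one five-membered non-aromatic ring with 1 hetero atom) in place of a group of 8 heavy atoms (6 carbon, 2 oxygen; one five-membered non-aromatic ring with 1 hetero atom), on an aromatic carbon. Among the compounds with values here, the only measured step that bears on this kind of change is the one from compound 1 to compound 2, a swap of the oxolan-2-yl and oxolan-3-yl groups, and it stayed within the scatter. Compound 4 carries the oxolan-3-yl group of compound 1, so its number is expected to sit near that of compound 1 and within the scatter of compound 2, with the step of a 1.4-fold lower number from compound 2 to compound 4 (0.16 log units; within the scatter) expected to be small. Compound 4 is therefore estimated at 30 uL/min, between 12 uL/min and 75 uL/min.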

Compound 4, intrinsic clearance in a liver preparation (reported as CLH), per the amount of preparation that the assay uses: 21.3 uL/min
Estimate against measurement, compound 4: 1.4-fold (0.15 log units) above, within the range that was stated.
By their numbers in this assay, from the lowest: compounds 4, 1 and 2 (each within the scatter of the next, the first and the last beyond it).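

Inverting both stereocentres of the group on the aromatic carbon gives a 1.2-fold lower number from compound 1 to compound 4 (0.07 log units; within the scatter), so in this assay this mirror-image pair cannot be told apart, and this is the first comparison shown in which nothing else changes: the fact that compounds 1 and 4 differ only in the configuration as drawn. The other new comparison, a 2.0-fold lower number from compound 2 to compound 4 (0.31 log units; beyond the scatter), is the first step among these compounds to pass beyond the scatter, yet it changes the oxolan-2-yl group to oxolan-3-yl and alters the drawn configuration at once, so it cannot be credited to either change alone. The step is modest, and the two smaller steps that link these compounds through compound 1 each stay within the scatter, so it deserves caution given how far repeats of a single compound can wander: the several entries of compound 3 in this assay, 136 uL/min; 93.3 uL/min; 128 uL/min; 108 uL/min (4 entries)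

The compounds shown leave open what happens when only one of the two stereocentres is inverted, since the only pair differing solely in configuration has both inverted. They also leave open how the number would respond if an amine or a carboxylic acid stood in place of the hydroxymethyl group on this chain.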